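Moving the fluorine on the benzylsulfonyl arm

This account rests on a few compounds, and the source may have more. Where it says the series, first, only, none or still open, it means among the compounds named here.

Compound 2 `N#Cc1cc2c(nc1N1CCC(C(=O)NS(=O)(=O)Cc3ccccc3F)CC1)COC2=O`: 23700 nM
Compound 1 `CC1OC(=O)c2cc(C#N)c(N3CC(C(=O)NS(=O)(=O)Cc4ccccc4)C3)nc21`: > 300000 nM

Going by the values given here, compound 2 gives 23700 nM in a functional assay (Platelet, plasma) for inhibition, with Homo sapiens as the target (on this read-out lower numbers stand for stronger inhibition and higher numbers for weaker inhibition), the only number measured so far. Compound 1 gives only a limit, > 300000 nM, in this assay, as the limit of > 300000 nM in this assay, at which 1 of the 2 values shown sits, records. Compound 3, `N#Cc1cc2c(nc1N1CCC(C(=O)NS(=O)(=O)Cc3ccc(F)cc3)CC1)COC2=O`, differs from compound 2 by one change: 4-fluorophenyl in place of 2-fluorophenyl on a saturated chain carbon bound to a sulfonyl sulfur. Among the compounds with values here, no measured step covers such a change, so the expectation rests on compound 2 alone. In this assay the step from compound 2 to compound 3 is expected to be small, no larger than the scatter, in either direction: a 1.1-fold higher number from compound 2 to compound 3 (0.02 log units; within the scatter). Compound 3 is therefore estimated at 25000 nM, with a range from 8000 nM to 80000 nM.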

Compound 3, half-maximal inhibitory concentration: 3500 nM
Beside the measured number, compound 3's estimate is 7.1-fold (0.85 log units) above it; the whole stated range lies above it.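

In this assay, the exchange of 2-fluorophenyl for 4-fluorophenyl on a saturated chain carbon bound to a sulfonyl sulfur gives a 6.8-fold lower number from compound 2 to compound 3 (0.83 log units; beyond the scatter), with the atoms of the two compounds unchanged. This shows that the read-out responds to where the fluorine sits on this ring, which a single value and a limit could not show. Nothing available explains this difference. The compounds shown leave open how a chlorine or a methoxy group in place of the fluorine would read.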